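The compounds below may be only part of what the source reports. "The series", "measured", "known", "first", "only" and "open" are said of these compounds alone.

Working notes on the series. The read-out throughout is an assay on NK92 cells for inhibition of interleukin-2 (Homo sapiens), read by AlphaScreen, with stated times of 30 min and 1 h; on this read-out lower numbers stand for stronger inhibition and higher numbers for weaker inhibition. Compound 1 `Cn1nc(Cc2nnc(SCCCCCCCC(=O)Nc3ccc(Cl)cc3Cl)n2CCC(=O)O)c2ccccc2c1=O` gives 14300 nM in this assay. Compound 2 `Cn1c(Cc2nn(CCC3OCCO3)c(=O)c3ccccc23)nnc1SCC(=O)Nc1ccc(Cl)cc1Cl` is reported in this assay only as a limit of > 30000 nM, not as a number. Compound 2 therefore stands at the weak end of the two values shown, at the limit itself (the limit of > 30000 nM in this assay, at which 1 of the 2 values shown sits), and the gap from compound 1 cannot be sized beyond saying that compound 1 returned a number and compound 2 did not.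

The step to compound 3 `CN(C)CCCn1nc(Cc2nnc(SCC(=O)Nc3ccc(Cl)cc3Cl)n2C)c2ccccc2c1=O` is a single change, (dimethylamino)methyl in place of 1,3-dioxolan-2-yl on a saturated chain carbon, two bonds along the chain from an aromatic nitrogen. Among the compounds with values here, no measured pair reports this kind of change, so no direction is given by the data. Compound 3 is expected near the weak end, estimated at 20000 nM in this assay, in a range from 6000 nM to 60000 nM, with a fair chance that only a limit is returned. The implied step, from compound 2 to compound 3, is expected as an at least 1.5-fold lower number from compound 2 to compound 3 (0.17 log units; that floor lies within the scatter), not clearly beyond the scatter.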

Compound 3, half-maximal inhibitory concentration: > 30000 nM
Compound 3: a limit, no number (the forecaster's own chance of this, stated with the estimate: 40%); at least 1.5-fold (0.17 log units) between middle value and limit.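

No step can be read from compound 2 to compound 3, as each is reported only as a limit: the limit of > 30000 nM in this assay, at which 2 of the 3 values shown sit.

The compounds shown leave open whether (dimethylamino)methyl in place of 1,3-dioxolan-2-yl on the saturated chain carbon changes the read-out at all, and in which direction.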